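The compounds below may be only part of what the source reports. "The series", "measured", "known", "first", "only" and "open" are said of these compounds alone.

Two compounds of this series carry numbers in a functional assay on MCF7 cells (Homo sapiens) for antiproliferative activity, read by MTT assay, with a stated time of 72 h; on this read-out lower numbers stand for stronger inhibition of growth and higher numbers for weaker inhibition of growth. Compound 1 `Brc1cccc(Nc2nc3ncccc3n2Cc2ccccc2)c1` gives 78700 nM in this assay. Compound 2 `Cc1ccc(Nc2nccc(-c3nn(C)c4ccccc34)n2)cc1` gives 6100 nM in this assay, the lower of the two numbers, and compound 1 stands well above it, beyond the scatter. Within the data shown here, no pair of measured compounds differs in a single place, so no measured step separates a single change from the rest.

Compound 3 `Cn1nc(-c2ccnc(Nc3cccc(Cl)c3)n2)c2ccccc21` has not yet been measured in this assay. It differs from compound 2 in one place: 3-chlorophenyl in place of 4-methylphenyl on a nitrogen on an aromatic ring. Among the measured compounds shown here, no measured step tracks this change. Without such a step, the change is expected to move the number by no more than a small amount in either direction, likely within the scatter, and the step of a 1.2-fold lower number from compound 2 to compound 3 (0.09 log units; within the scatter) is estimated accordingly. Compound 3 is expected to give 5000 nM in this assay, with a range from 1500 nM to 20000 nM.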

Compound 3, concentration for 50% growth inhibition: 5970 nM
Compound 3: middle estimate off by 1.2-fold (0.08 log units), on the low side, within the range that was stated.
By their numbers in this assay, from the lowest: compounds 3 and 2 (each within the scatter of the next); then compound 1.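

In this assay, among these compounds, the first single-place step reads a 1.0-fold lower number from compound 2 to compound 3 (0.01 log units; within the scatter) and so lies within the scatter. On the shared core, (3-chlorophenyl)amino and (4-methylphenyl)amino therefore cannot be told apart on this read-out, and this position on the nitrogen takes either group without the number leaving the scatter. Nothing available bears on why the two compounds read alike.

This step joins two differences in one, chlorine for methyl and the 3 for the 4 in the group's name, and the compounds shown do not separate them. Also open, as far as these compounds go, is whether the number stays put with a group of another kind on this nitrogen, such as a phenyl ring carrying a carboxylic acid or an amine on a longer chain.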